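The source may report more compounds than this note shows. Statements on the series, on what has been measured and on what is new or still open speak of the compounds shown alone.

In a functional assay on PANC-1 cells (Homo sapiens) for inhibition, read by MTT assay, with a stated time of 24 h (on this read-out higher numbers stand for weaker inhibition and lower numbers for stronger inhibition), compound 2 `COc1ccccc1NC(=O)Oc1cc(=O)n(CCCO)c2c1CC(CC=C(C)C)C(C)(C)C2` gives 7700 nM, which lies within the scatter of compound 1 `CCOc1cc(=O)n(CCCO)c2c1CC(CC=C(C)C)C(C)(C)C2` at 7300 nM. Compound 3 `CC(C)=CCC1Cc2c(OC(=O)Nc3ccc(F)cc3)cc(=O)n(CCCO)c2CC1(C)C` has 4-fluorophenyl in place of 2-methoxyphenyl on an amide-type nitrogen. For the measured compounds named here, only one measured step bears on this change, and it is indirect. Putting (2-methoxyphenyl)carbamoyl in place of ethyl gave a 1.1-fold higher number from compound 1 to compound 2 (0.02 log units; within the scatter), so even that swap did not move the number beyond the scatter. Going by the values given here, no measurement yet tests a change of this phenyl group itself, so no shift beyond the scatter is expected in this assay. The expected change is a 1.2-fold lower number from compound 2 to compound 3 (0.07 log units; within the scatter). For compound 3 the estimate is 6500 nM, with an expected range of 2500 nM to 15000 nM.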

Compound 3, half-maximal inhibitory concentration: 7700 nM
For compound 3 the middle estimate is 1.2-fold (0.07 log units) below the measured one; measured number inside the range.
By their numbers in this assay, from the lowest: compounds 1, 2 and 3 (each within the scatter of the next).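

In this assay, for the compounds shown here, putting 4-fluorophenyl in place of 2-methoxyphenyl on the amide-type nitrogen is the first direct test of this phenyl group, and it gives no change at the digits printed from compound 2 to compound 3 (within the scatter) in that read-out. Replacing ethyl with (4-fluorophenyl)carbamoyl gives a 1.1-fold higher number from compound 1 to compound 3 (0.02 log units; within the scatter) as well, so two different carbamoyl groups now lie within the scatter of the ethyl compound. Nothing available explains this flat result. Still open, on these data alone, is whether an amine or a carboxylic acid on this phenyl ring, or a longer chain in its place, would move the number beyond the scatter.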